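Terminal amino group replacing the alkyl chain end

The source may hold more compounds than are shown below. What is called first, only, known or untested is meant among the compounds shown, and "the series" means these compounds.

Measured compounds:
compound 1 `CCCCCNCc1c(O)ccc2ccc(=O)oc12` — 59000 nM
compound 2 `CCNCc1c(O)ccc2ccc(=O)oc12` — 52000 nM

Among the measured compounds shown here, compound 1 gives the highest of the two numbers so far in an assay on isolated protein for inhibition of seed linoleate 13S-lipoxygenase-1 (Glycine max); on this read-out lower numbers stand for stronger inhibition and higher numbers for weaker inhibition; compound 2, with its hydrogen in place of propyl, sits within the scatter of it, so no order between the two can be read. For the measured compounds named here, the step of a 1.1-fold lower number from compound 1 to compound 2 (0.05 log units; within the scatter) is the only measured step and shows that removing propyl from the saturated chain carbon two bonds along the chain from the amine nitrogen leaves this assay essentially unchanged.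

Compound 3 `NCCCNCc1c(O)ccc2ccc(=O)oc12` differs from compound 1 by amino in place of ethyl on a saturated chain carbon, three bonds along the chain from an amine nitrogen. Going by the values given here, the measured step bears on it only in part: it concerns the same chain, but it trims the chain rather than ending it in an amino group, and no measured pair introduces a hydrogen-bond donor or acceptor at this place. Among the compounds with values here, with the single relevant step lying within the scatter, no shift beyond the scatter is expected for compound 3 in this assay, and the expected step is a 1.2-fold lower number from compound 1 to compound 3 (0.07 log units; within the scatter). The estimate for compound 3 is 50000 nM, expected to fall between 18000 nM and 140000 nM.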

Compound 3, half-maximal inhibitory concentration: >> 1000000 nM
Compound 3: no number, only a limit; the forecaster's own chance of this, stated with the estimate: 15%; at least 20-fold (1.30 log units) between middle value and limit.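

In this assay compound 3 gives a limit of the assay and not a number: the limit of >> 1000000 nM in this assay, at which 1 of the 3 values shown sits. Amino in place of ethyl on a saturated chain carbon, three bonds along the chain from an amine nitrogen, gives an at least 16-fold higher number from compound 1 to compound 3 (1.22 log units; beyond the scatter), and set against the shorter chain the same compound gives an at least 19-fold higher number from compound 2 to compound 3 (1.28 log units; beyond the scatter). The earlier step, a 1.1-fold lower number from compound 1 to compound 2 (0.05 log units; within the scatter), showed only that trimming this chain leaves the read-out unchanged, whereas these two steps show that the chain end is not indifferent, since the 3-aminopropyl chain stands well apart from both the pentyl and the ethyl chain.

The compounds shown leave open whether this large step belongs to a terminal amine as such or would also follow from a terminal hydroxyl, a carboxylic acid or an acetamide at the chain end, and whether a longer chain carrying the amino group would behave in the same way. As far as these compounds go, with only a limit for compound 3, the full size of the step also remains open.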